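The compounds below may be only part of what the source reports. "The series", "measured", "known", "first", "only" and "open" are said of these compounds alone.

Compound 1 `COc1ccc(-c2cc3ccccc3nc2/C=C/C(=O)c2ccc(OC)cc2OC)cc1` gives 2260 nM in a functional assay on SK-BR-3 cells (Homo sapiens) for antiproliferative activity, read by XTT assay, with a stated time of 72 h (on this read-out lower numbers stand for stronger inhibition and higher numbers for weaker inhibition), the lower of the two numbers measured; compound 2 `COc1ccc(-c2cc3ccccc3nc2/C=C/C(=O)c2ccc(OC)c(OC)c2)cc1` gives 3260 nM, and the step of a 1.4-fold higher number from compound 1 to compound 2 (0.16 log units; within the scatter) does not leave the scatter. Compound 3 `COc1ccc(-c2cc3ccccc3nc2/C=C/C(=O)c2ccc[nH]2)cc1` differs from compound 1 by 1H-pyrrol-2-yl in place of 2,4-dimethoxyphenyl on a carbonyl carbon. Among the measured compounds shown here, no measured step concerns this change: the only step on record swaps one dimethoxyphenyl pattern for another, so the account offers no direct guide to the pyrrolyl replacement. Compound 3 is therefore expected near compound 1, with a step of a 1.1-fold higher number from compound 1 to compound 3 (0.04 log units; within the scatter) and a wide range. The estimate for compound 3 is 2500 nM, between 700 nM and 9000 nM.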

Compound 3, half-maximal inhibitory concentration: > 10000 nM
Compound 3 was reported as a limit (the forecaster's own chance of this, stated with the estimate: 10%); middle value at least 4.0-fold (0.60 log units) from the limit.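

Compound 3 stands only as a limit: the limit of > 10000 nM in this assay, at which 1 of the 3 values shown sits. The earlier swap of one dimethoxyphenyl pattern for another stayed within the scatter, whereas 1H-pyrrol-2-yl on a carbonyl carbon gives an at least 4.4-fold higher number from compound 1 to compound 3 (0.64 log units; beyond the scatter) and an at least 3.0-fold higher number from compound 2 to compound 3 (0.48 log units; beyond the scatter). The group at this position therefore does matter on this read-out, which the first two compounds could not show.

As far as these compounds go, it remains open whether the loss of the methoxy groups, the five-membered ring or the ring nitrogen with its hydrogen counts. Plain phenyl, 2-furyl or 1-methylpyrrol-2-yl at this position would bear on that question.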